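Phenyl for thiophen-3-yl on the shared core

This account rests on a few compounds, and the source may have more. Where it says the series, first, only, none or still open, it means among the compounds named here.

Measured compounds:
compound 1 `Oc1ccc(-c2cc(-c3ccsc3)nc(-c3cccc(Cl)c3)c2)cc1`: 5760 nM
compound 2 `Oc1ccc(-c2cc(-c3ccsc3)nc(-c3ccccc3Cl)c2)cc1`: 5830 nM

In a functional assay on HCT-15 cells (Homo sapiens) for cytotoxicity, read by CCK-8 assay and cell counting, with a stated time of 2 days (on this read-out lower numbers stand for stronger inhibition and higher numbers for weaker inhibition), compound 1 gives 5760 nM and compound 2 gives 5830 nM. Compound 1 and compound 2 sit together: the step of a 1.0-fold higher number from compound 1 to compound 2 (0.01 log units; within the scatter) lies within the scatter, so neither stands apart. Compound 3 `Oc1ccc(-c2cc(-c3ccccc3)nc(-c3cccc(Cl)c3)c2)cc1` is unmeasured and differs from compound 1 by phenyl in place of thiophen-3-yl on an aromatic carbon. Going by the values given here, the only measured step, a 1.0-fold higher number from compound 1 to compound 2 (0.01 log units; within the scatter), concerns the 3-chlorophenyl group, not the thiophen-3-yl group, so no measured step bears directly on this change. A step of a 1.0-fold lower number from compound 1 to compound 3 (0.02 log units; within the scatter) is expected, not beyond the scatter. Compound 3 is estimated at 5500 nM, in the range 2200 nM to 14000 nM.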

Compound 3, half-maximal inhibitory concentration: 6100 nM
Estimate against measurement, compound 3: 1.1-fold (0.04 log units) below, and the stated range covers the measured number.
By their numbers in this assay, from the lowest: compounds 1, 2 and 3 (each within the scatter of the next).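

Phenyl in place of thiophen-3-yl gives a 1.1-fold higher number from compound 1 to compound 3 (0.02 log units; within the scatter) in this assay, the first reading at this position, next to the ring nitrogen; the earlier pair varied only the chlorophenyl group. The two aromatic rings are not told apart here, even though the sulfur and the hydrogen-bond acceptor counted for thiophen-3-yl leave with this swap. No measured evidence on the compounds bears on this result.

Going by these compounds, whether an amine or a carboxylic acid at this position would stand apart from these compounds remains open. So does whether phenyl and thiophen-3-yl also match alongside the 2-chlorophenyl group of compound 2.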